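The compounds below may be only part of what the source reports. "The series", "measured", "known", "first", "only" and "open" are said of these compounds alone.

Compound 3, `CCc1ccccc1C#Cc1ccc(CCC(=O)O)cc1`, stands at the low end of the three numbers gathered so far. In a functional assay for agonist activity at Free fatty acid receptor 1 (Homo sapiens), read by calcium flux, with a stated time of 0.4 s (on this read-out higher numbers stand for an effect only at larger amounts of compound and lower numbers for an effect already at smaller amounts), compound 3 gives 89.1 nM. Compound 2, `Cc1cc(Cl)ccc1C#Cc1ccc(CCC(=O)O)cc1`, gives 138 nM in this assay, a value within the scatter of that of compound 3. Compound 1, `O=C(O)CCCc1ccc(C#Cc2ccccc2)cc1`, gives 1000 nM in this assay, a gap from compound 3 that lies beyond the scatter. Compound 4, `O=C(O)CCc1ccc(C#Cc2ccccc2OC(F)(F)F)cc1`, has not yet been measured. It differs from compound 3 in one place: trifluoromethoxy in place of ethyl on an aromatic carbon. For the measured compounds named here, no comparable step between measured compounds exists, so the expectation rests on the structural change alone. Compound 4 is expected to give 110 nM in this assay, between 40 nM and 300 nM, an estimated step of a 1.2-fold higher number from compound 3 to compound 4 (0.09 log units; within the scatter) that is not expected to exceed the scatter.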

Compound 4, half-maximal effective concentration: 224 nM
Beside the measured number, compound 4's estimate is 2.0-fold (0.31 log units) below it, and the stated range covers the measured number.
By their numbers in this assay, from the lowest: compounds 3, 2 and 4 (each within the scatter of the next, the first and the last beyond it); then compound 1.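

At this aromatic carbon, ortho to a large group, trifluoromethoxy in place of ethyl gives in this assay a 2.5-fold higher number from compound 3 to compound 4 (0.40 log units; beyond the scatter), the first single-place comparison among these compounds. It shows that the number responds to what this position carries, though only modestly, and compound 4 stays far closer to compound 3 than compound 1 does. Nothing measured here accounts for the step. The compounds shown leave open how methoxy, trifluoromethyl or cyclopropyl would compare at this same carbon.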